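The compounds below may be only part of what the source reports. "The series", "measured", "known", "first", "only" and "open" are said of these compounds alone.

Measured so far:
- compound 1, `COc1ccc(SCc2ccc(C(=O)Nc3ccccc3N)cc2)cc1`: 80.1%
- compound 2, `CC(C)(C)c1ccc(SCc2ccc(/C=C/C(=O)Nc3ccccc3N)cc2)cc1`: 23.6%
- compound 3, `Nc1ccccc1NC(=O)/C=C/c1ccc(CSc2cccc3ccccc23)cc1`: 18.3%

In a functional assay on SMMC-7721 cells (Homo sapiens) for inhibition, read by CCK-8 assay, with a stated time of 72 h, tested at 8 uM (a higher number here means more inhibition of growth at the concentration tested, a lower number less inhibition of growth), compound 1 gives 80.1%, the highest of the three numbers; compound 2 gives 23.6% and compound 3 gives 18.3%, each of them below compound 1 by a gap beyond the scatter. Among the compounds with values here, the only step between measured compounds that differ in one place, a number 5.3 percentage points lower from compound 2 to compound 3 (within the scatter), concerns a swap of the whole aryl group on the sulfur and stays within the scatter.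

Compound 4, `Nc1ccccc1NC(=O)c1ccc(CSc2ccc(F)cc2)cc1`, is the next compound and differs from compound 1 as follows: fluoro in place of methoxy on an aromatic carbon. Within the data shown here, no measured step covers an exchange of a small substituent on the aryl bound to sulfur; the step from compound 2 to compound 3 is the closest case, and it was flat. Since that one swap on the sulfur-bound aryl gave no change beyond the scatter, a small step is expected here too, if anything slightly downward, as a number 8.1 percentage points lower from compound 1 to compound 4 (within the scatter). Compound 4 is therefore estimated at 72%, with a range from 52% to 88%.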

Compound 4, percent growth inhibition at one concentration: 81.9%
Estimate against measurement, compound 4: 9.9 percentage points below; the measured number falls inside the stated range.
By their numbers in this assay, from the lowest: compounds 3 and 2 (each within the scatter of the next); then compounds 1 and 4 (each within the scatter of the next).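

In this assay, within the data shown here, fluoro in place of methoxy on an aromatic carbon gives a number 1.8 percentage points higher from compound 1 to compound 4 (within the scatter), the first measured step that changes only a small substituent on the aryl bound to sulfur, and the first within the core of compound 1. The methoxy oxygen is therefore not needed at this position to keep the growth inhibition seen at this single concentration. Nothing available explains why the exchange leaves the number within the scatter.

As far as these compounds go, whether an amine, a carboxylic acid or a longer alkoxy chain at the same position would hold the number remains open. From the compounds shown here alone, it is also open whether compound 1 and compound 4 would stay within the scatter of each other at other concentrations.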